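Aryl swap on the fluoro core: an expectation

A few compounds are considered here, and "the series" means these few. Any claim that something is new, unique, unknown or untested is made for them only; others in the source may bear on it.

Three compounds have been measured in an assay on isolated protein for displacement of a labelled ligand from metabotropic glutamate receptor 5 (Homo sapiens), with a stated time of 60 min, tested at 1 uM; a lower number here means less inhibition, a higher number more inhibition at the concentration tested (going by the name of the read-out):
compound 1 `Cc1ccc(S(=O)(=O)c2cnc3ccc(Cl)cc3c2N2CCC(C)CC2)cc1F` gives 68%
compound 2 `CC1CCN(c2c(S(=O)(=O)c3ccccc3)cnc3ccc(Cl)cc23)CC1` gives 59%
compound 3 `CC1CCN(c2c(S(=O)(=O)c3ccccc3)cnc3ccc(F)cc23)CC1` gives 40%

Compound 1 differs from compound 2 by 3-fluoro-4-methylphenyl in place of phenyl on a sulfonyl sulfur, and this step gives a number 9 percentage points higher from compound 2 to compound 1 (within the scatter). Compound 3 differs from compound 2 by fluoro in place of chloro on an aromatic carbon, a step of a number 19 percentage points lower from compound 2 to compound 3 (beyond the scatter), leaving compound 3 as the lowest of the three.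

Compound 4 `Cc1ccc(S(=O)(=O)c2cnc3ccc(F)cc3c2N2CCC(C)CC2)cc1F` is not yet measured. It differs from compound 3 by 3-fluoro-4-methylphenyl in place of phenyl on a sulfonyl sulfur, which is the same change as that from compound 2 to compound 1, made at the same place on the core of compound 3. Because the earlier step was a number 9 percentage points higher from compound 2 to compound 1 (within the scatter), compound 4 is expected to show a step of about a number 9 percentage points higher from compound 3 to compound 4 (within the scatter) from compound 3. Compound 4 is therefore estimated at 49%, likely between 35% and 62% in this assay.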

Compound 4, a percentage reported as inhibition, at one concentration (the size of the read-out at that concentration, not a potency): 86%
Compound 4: middle estimate off by 37 percentage points, on the low side; measured number outside the range, above it.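

In this assay, 3-fluoro-4-methylphenyl in place of phenyl on the sulfonyl sulfur gives a number 46 percentage points higher from compound 3 to compound 4 (beyond the scatter), and fluoro in place of chloro gives a number 18 percentage points higher from compound 1 to compound 4 (beyond the scatter). The size of the aryl step therefore did not carry over from one core to the other: the same change on two cores in this assay, a number 9 percentage points higher (within the scatter) from compound 2 to compound 1 and a number 46 percentage points higher (beyond the scatter) from compound 3 to compound 4, 37 percentage points apart, beyond the scatter of two such steps. The halogen step also depends on the aryl group present, though these four compounds do not show why, nor how either change would behave on another core: the same change on two cores in this assay, a number 19 percentage points lower (beyond the scatter) from compound 2 to compound 3 and a number 18 percentage points higher (beyond the scatter) from compound 1 to compound 4, 37 percentage points apart, beyond the scatter of two such steps.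

The compounds shown leave open whether a simple 4-methylphenyl or 3-fluorophenyl group would give the same jump on the fluoro core. They also leave open how a methoxy group or a nitrile would behave in place of the halogen.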